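Flipping the Double Bond of a Brominated Enone

The source may report more compounds than this note shows. Statements on the series, on what has been measured and on what is new or still open speak of the compounds shown alone.

In a functional assay on SW1573 cells (Homo sapiens) for inhibition, read by sulforhodamine B assay, with a stated time of 48 h (on this read-out higher numbers stand for weaker inhibition of growth and lower numbers for stronger inhibition of growth), the measured compounds are:
compound 1 `CC(=O)OC/C(=C\c1ccccc1)C(=O)c1ccccc1` gives 4800 nM;
compound 2 `CC(=O)OC/C(=C\c1ccc(F)cc1)C(=O)c1ccccc1` gives 4200 nM;
compound 3 `CC(=O)OC/C(=C\c1ccccc1Br)C(=O)c1ccccc1` gives 14000 nM.

Compound 3 stands with the highest number of the three in this assay: a 2.9-fold higher number from compound 1 to compound 3 (0.46 log units; beyond the scatter) and a 3.3-fold higher number from compound 2 to compound 3 (0.52 log units; beyond the scatter). Compound 1 and compound 2 lie within the scatter of each other, a 1.1-fold lower number from compound 1 to compound 2 (0.06 log units; within the scatter). Compound 4 `CC(=O)OC/C(=C/c1ccccc1Br)C(=O)c1ccccc1` is the geometric counterpart of compound 3: the two compounds have the same atoms and bonds and differ only in configuration as drawn: 1 of 1 stereo elements differ; a double bond is drawn E in compound 3 and Z in compound 4. Going by the values given here, none of the measured steps touches the double-bond geometry; each swaps a substituent on an aromatic carbon, so no measured step bears directly on this change. The number for compound 4 is therefore expected to stay near that of compound 3, with no change at the digits printed from compound 3 to compound 4 (within the scatter) expected to fall within the scatter, though the lack of any geometric comparison leaves the range wide. Compound 4 is estimated at 14000 nM, between 4000 nM and 50000 nM.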

Compound 4, concentration for 50% growth inhibition: 21000 nM
Beside the measured number, compound 4's estimate is 1.5-fold (0.18 log units) below it, and the stated range covers the measured number.
By their numbers in this assay, from the lowest: compounds 2 and 1 (each within the scatter of the next); then compounds 3 and 4 (each within the scatter of the next).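

Among the compounds shown, only this pair speaks to the double-bond geometry, and in this assay the change gives a 1.5-fold higher number from compound 3 to compound 4 (0.18 log units; within the scatter). With the 2-bromophenyl group in place, the E and Z drawings are thus not separated beyond the scatter. The pair isolates that single feature: the fact that compounds 3 and 4 differ only in the configuration as drawn

On these data alone, whether the geometry counts for as little with the phenyl of compound 1 or the 4-fluorophenyl of compound 2 remains open. So does the outcome for either geometry if an amine or a carboxylic acid stands in place of the acetate.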